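Chloro to trifluoromethyl swap: cytotoxicity notes on the series

A few compounds are considered here, and "the series" means these few. Any claim that something is new, unique, unknown or untested is made for them only; others in the source may bear on it.

Compound 1 `CC1(C)C[C@H](O)C[C@](C)(CNc2cccc(Cl)c2)C1`, compound 2 `CC1(C)C[C@H](O)C[C@](C)(CNc2cccc(C(F)(F)F)c2)C1` and compound 3 `CC1(C)C[C@H](O)C[C@](C)(CNc2cc(Cl)cc(S(N)(=O)=O)c2)C1` share one core; compound 4 `CC1(C)C[C@H](O)C[C@](C)(CNc2cc(C(F)(F)F)cc(S(N)(=O)=O)c2)C1` is not yet measured. In an ADME assay on MDCK cells (Canis lupus familiaris) for cytotoxicity, read by MTT assay, with a stated time of 3 days (on this read-out lower numbers stand for higher toxicity in this test and higher numbers for lower toxicity in this test), compound 1 gives 9700 nM, compound 2 gives 7800 nM and compound 3 gives 8400 nM. The change trifluoromethyl in place of chloro on an aromatic carbon gave a 1.2-fold lower number from compound 1 to compound 2 (0.09 log units; within the scatter). The core of compound 3 differs from that of compound 1 by sulfamoyl in place of hydrogen on an aromatic carbon, with a 1.2-fold lower number from compound 1 to compound 3 (0.06 log units; within the scatter). The change trifluoromethyl in place of chloro on an aromatic carbon is the same kind of change as that from compound 1 to compound 2, but here the place is also meta to a sulfamoyl group (4 heavy atoms). Because a 1.2-fold lower number from compound 1 to compound 2 (0.09 log units; within the scatter) stayed within the scatter, the step of a 1.2-fold lower number from compound 3 to compound 4 (0.08 log units; within the scatter) is expected to be of similar size. Compound 4 is therefore estimated at 7000 nM in this assay, with an expected range from 3500 nM to 14000 nM.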

Compound 4, half-maximal cytotoxic concentration: 19500 nM
Compound 4: the middle estimate sits 2.8-fold (0.44 log units) below what was measured, and the stated range ends below it.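

In this assay, trifluoromethyl in place of chloro gave a 2.3-fold higher number from compound 3 to compound 4 (0.37 log units; beyond the scatter) with the sulfamoyl group present, so the step seen on the core of compound 1 did not carry over: the same change on two cores in this assay, a 1.2-fold lower number (0.09 log units; within the scatter) from compound 1 to compound 2 and a 2.3-fold higher number (0.37 log units; beyond the scatter) from compound 3 to compound 4, 2.9-fold (0.46 log units) apart, beyond the scatter of two such steps. Sulfamoyl in place of hydrogen gave a 2.5-fold higher number from compound 2 to compound 4 (0.40 log units; beyond the scatter) with trifluoromethyl present, and this step did not carry over either: the same change on two cores in this assay, a 1.2-fold lower number (0.06 log units; within the scatter) from compound 1 to compound 3 and a 2.5-fold higher number (0.40 log units; beyond the scatter) from compound 2 to compound 4, 2.9-fold (0.46 log units) apart, beyond the scatter of two such steps. Both gaps rest on compound 4 alone, so they show that the two changes do not simply add up in this set, but not why, nor whether this holds beyond these compounds.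

From the compounds shown here alone, whether a carboxylic acid or a nitrile in place of sulfamoyl would behave the same way remains open. So does the outcome with bromo or methyl in place of trifluoromethyl.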